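This account rests on a few compounds, and the source may have more. Where it says the series, first, only, none or still open, it means among the compounds named here.

Measured so far:
Compound 1, `COC(=O)c1ccc(NC(=O)Nc2cc(C)nc3ccccc23)cc1`, gives 21000 nM.
Compound 2, `Cc1cc(NC(=O)Nc2ccc(C(F)(F)F)cc2)c2ccccc2n1`, gives > 25000 nM.
Compound 3, `COC(=O)c1cccc(NC(=O)Nc2cc(C)nc3ccccc23)c1`, gives 21000 nM.

All three were tested in an ADME assay on BJ cells (Homo sapiens) for cytotoxicity, with a stated time of 72 h; on this read-out lower numbers stand for an effect already at smaller amounts and higher numbers for an effect only at larger amounts of compound. Compound 1 gives 21000 nM in this assay. For compound 2 the assay gives only a limit, > 25000 nM, not a number. Compound 3 gives 21000 nM in this assay, level with compound 1 at the digits shown.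

Compound 1 and compound 2 differ in one place: trifluoromethyl in place of methoxycarbonyl on an aromatic carbon. This change made an at least 1.1-fold higher number from compound 1 to compound 2 (0.07 log units; that floor lies within the scatter); the floor of that step comes from the limit of > 25000 nM in this assay, at which 1 of the 3 values shown sits.

Compound 3 is built from the same atoms as compound 1, joined differently; the difference between the two cores is not broken down here. Compound 4, `Cc1cc(NC(=O)Nc2cccc(C(F)(F)F)c2)c2ccccc2n1`, has not yet been measured in this assay. It stands to compound 3 as compound 2 stands to compound 1: trifluoromethyl in place of methoxycarbonyl on an aromatic carbon. The surroundings are not the same word for word, since in compound 1 the group sits para to a large group and in compound 3 meta to a large group, so this is the same kind of change rather than the same change.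

Resting on the step that the change made from compound 1 to compound 2, compound 4 is expected to move by about a 1.4-fold higher number from compound 3 to compound 4 (0.15 log units; within the scatter) from compound 3. Compound 4 is therefore estimated at 30000 nM in this assay, somewhere between 15000 nM and 60000 nM, with a fair chance that only a limit is reported.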

Compound 4, half-maximal effective concentration in the BJ assay: > 25000 nM
Compound 4 gave a limit, no number (the forecaster's own chance of this, stated with the estimate: 55%); the middle value does not contradict the limit.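

In the BJ assay, trifluoromethyl in place of methoxycarbonyl gives an at least 1.1-fold higher number from compound 3 to compound 4 (0.07 log units; that floor lies within the scatter), and set beside the earlier step on the other core, the comparison reads: the same change on two cores in the BJ assay, an at least 1.1-fold higher number (0.07 log units; that floor lies within the scatter) from compound 1 to compound 2 and an at least 1.1-fold higher number (0.07 log units; that floor lies within the scatter) from compound 3 to compound 4; the limit leaves it open whether they differ. Going by these compounds alone, this shows only that compound 2 and compound 4, the two trifluoromethyl compounds, both end at a limit rather than a number, so the true size of the step on either core stays unknown and the two steps cannot be called equal or different: the limit of > 25000 nM in the BJ assay, at which 2 of the 4 values shown sit. In a physicochemical assay for solubility, at pH 7.4 (on this read-out lower numbers stand for lower solubility and higher numbers for higher solubility), compound 3 gives 600 nM and compound 4 gives 100 nM. In the physicochemical assay the change does have a measured size on the core of compound 3, but this single pair shows nothing about how the change behaves on the core of compound 1: the measured solubility of compound 3, 600 nM, and of compound 4, 100 nM, a 6.0-fold lower number (0.78 log units; beyond the scatter).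

The compounds shown leave open whether the step in the physicochemical assay would have the same size on the core of compound 1. They also leave open what a carboxylic acid, an amine or a nitrile on that aromatic carbon would do in the BJ assay and in the physicochemical assay.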